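A few compounds are considered here, and "the series" means these few. Any claim that something is new, unique, unknown or untested is made for them only; others in the source may bear on it.

Compound 2, whose structure is `CCc1ccc(-c2nc(CNc3ccc(C(=O)NO)cc3)n(-c3ccccc3)n2)cc1`, is the lower of the two measured compounds: in an assay on Sf9 cells for inhibition of protein deacetylase HDAC6 (Homo sapiens), read by fluorescence, with a stated time of 40 min, tested at 100 nM (a higher number here means more inhibition at the concentration tested (going by the name of the read-out), a lower number less inhibition), compound 2 gives 54.6%. For the measured compounds named here, compound 1, with the structure `O=C(NO)c1ccc(NCc2nc(-c3ccc(F)cc3)nn2-c2ccccc2)cc1`, gives 70.9% in this assay, and the only measured step, a number 16.3 percentage points lower from compound 1 to compound 2 (beyond the scatter), is ethyl in place of fluoro on an aromatic carbon. Compound 3, whose structure is `CC(C)c1ccc(-c2nc(CNc3ccc(C(=O)NO)cc3)n(-c3ccccc3)n2)cc1`, has not yet been measured in this assay. It differs from compound 2 by methyl in place of hydrogen on a saturated chain carbon bound to an aromatic carbon and a saturated chain carbon, so that the ethyl of compound 2 becomes an isopropyl on the same 4-substituted phenyl. Going by the values given here, the one step in hand bears on this only indirectly: it shows that enlarging the group on that aromatic carbon from fluoro to ethyl cost a modest amount of inhibition, and a further methyl on the saturated chain carbon may continue in the same direction or stay within the scatter. Compound 3 is therefore expected to show a small loss, a number 6.6 percentage points lower from compound 2 to compound 3 (within the scatter), and its value in this assay is estimated at 48%, within a range of 28% to 66%.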

Compound 3, a percentage reported as inhibition, at one concentration (the size of the read-out at that concentration, not a potency): 27.6%
Estimate against measurement, compound 3: 20.4 percentage points above; the whole stated range lies above it.
By their numbers in this assay, from the lowest: compound 3; then compound 2; then compound 1.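

Going from ethyl to isopropyl on the phenyl group gives, in this assay, a number 27 percentage points lower from compound 2 to compound 3 (beyond the scatter), so a single added methyl on the saturated chain carbon is enough to shift the reading at this position, which the one earlier step, from fluoro to ethyl, could not show. Replacing fluoro with isopropyl gives a number 43.3 percentage points lower from compound 1 to compound 3 (beyond the scatter), a large step that makes this aromatic carbon a clearly sensitive site, and the three compounds now fall in a single order, fluoro, then ethyl, then isopropyl, with none of them going against it. Nothing available explains the loss of inhibition that comes with these groups.

Three groups cannot settle whether the number keeps falling with a further branched group such as tert-butyl, or whether an unbranched longer chain such as propyl behaves like ethyl or like isopropyl. As far as these compounds go, it also remains open how a methoxy group, an amine or a carboxylic acid on the same aromatic carbon would read, and, since the read-out comes from one concentration, how far these differences would carry over to potency.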